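Swapping the aryl group on a bis(chlorophenyl) core

The source may hold more compounds than are shown below. What is called first, only, known or untested is meant among the compounds shown, and "the series" means these compounds.

Measured compounds in a functional assay on SMMC-7721 cells (Homo sapiens) for cytotoxicity, read by MTT assay, with a stated time of 72 h; a higher number here means a weaker inhibitor, a lower number a stronger inhibitor:
compound 1 `CN(C)c1ccc(C=C2C(=O)N(c3ccc(Cl)cc3)N(c3ccc(Cl)cc3)C2=O)cc1` gives > 128000 nM, a limit of the assay rather than a number;
compound 2 `O=C1C(=Cc2ccc(F)cc2)C(=O)N(c2ccc(Cl)cc2)N1c1ccc(Cl)cc1` gives 23300 nM;
compound 3 `COc1cc(C=C2C(=O)N(c3ccc(Cl)cc3)N(c3ccc(Cl)cc3)C2=O)ccc1O` gives 64900 nM.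

Compound 1 stands at the limit described by the limit of > 128000 nM in this assay, at which 1 of the 3 values shown sits, so only a floor is known for it, not a value. Compound 4 `COc1cccc(C=C2C(=O)N(c3ccc(Cl)cc3)N(c3ccc(Cl)cc3)C2=O)c1OC` differs from compound 1 in one place: 2,3-dimethoxyphenyl in place of 4-(dimethylamino)phenyl on a double-bonded chain carbon bound to a double-bonded ring carbon. Two measured steps start from compound 1 and also change the aryl group on the double-bonded chain carbon. The first, an at least 5.4-fold lower number from compound 1 to compound 2 (0.73 log units; beyond the scatter), is beyond the scatter. The second, an at least 1.9-fold lower number from compound 1 to compound 3 (0.29 log units; that floor lies within the scatter), has a floor that lies within the scatter. Between those two aryl groups, a 2.8-fold higher number from compound 2 to compound 3 (0.44 log units; beyond the scatter), a modest change. Both measured replacements of the 4-(dimethylamino)phenyl group therefore move the number downward, so compound 4, which carries a 2,3-dimethoxyphenyl group, is expected to show a lower number than the limit of compound 1, probably of a size between the two measured steps. The expected step is an at least 2.5-fold lower number from compound 1 to compound 4 (0.40 log units; beyond the scatter). Compound 4 is accordingly estimated to give 50000 nM, within a range from 20000 nM to 128000 nM.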

Compound 4, half-maximal inhibitory concentration: 14100 nM
Compound 4: middle estimate off by 3.5-fold (0.55 log units), on the high side; measured number below the stated range.
By their numbers in this assay, from the lowest: compounds 4 and 2 (each within the scatter of the next); then compound 3. At a limit, above all of these: compound 1.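

In this assay, going by these compounds, the 2,3-dimethoxyphenyl group at this position, on a double-bonded chain carbon bound to a double-bonded ring carbon, gives the largest floor yet for a replacement of the 4-(dimethylamino)phenyl group (an at least 9.0-fold lower number from compound 1 to compound 4 (0.95 log units; beyond the scatter)), and the true size of that step stays unknown because compound 1 sits at a limit: the limit of > 128000 nM in this assay, at which 1 of the 4 values shown sits. The oxygen-bearing groups at this position do not behave alike, as changing the 4-hydroxy-3-methoxyphenyl group to the 2,3-dimethoxyphenyl group gives a step beyond the scatter (a 4.6-fold lower number from compound 3 to compound 4 (0.66 log units; beyond the scatter)). The 4-fluorophenyl and 2,3-dimethoxyphenyl groups, different as they are, cannot be told apart here, since their step lies within the scatter (a 1.7-fold lower number from compound 2 to compound 4 (0.22 log units; within the scatter)).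

The compounds shown leave open how a plain phenyl group, or a phenyl group carrying a single methoxy group, would read at this position, so they do not settle whether both methoxy groups of compound 4 are needed. They also leave open how this position would respond to a phenyl group carrying a carboxylic acid or a primary amine.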